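The compounds below may be only part of what the source reports. "The series", "measured", "known", "first", "only" and "open" are said of these compounds alone.

Measured compounds:
Compound 1, `O=C(O)/C(S)=C/c1c[nH]c2c(I)cccc12`: 220 nM
Compound 2, `O=C(O)/C(S)=C/c1cccc(Br)c1`: 8400 nM
Compound 3, `O=C(O)/C(S)=C/c1c[nH]c2c(Br)cccc12`: 70 nM

All three were tested in an assay on isolated protein for inhibition of Calpain-1 catalytic subunit (Sus scrofa); on this read-out lower numbers stand for stronger inhibition and higher numbers for weaker inhibition. Compound 3 gives the lowest number of the three, compound 2 the highest; how the core of compound 2 differs from the core of compound 3 is not broken down here. Between compound 3 and compound 1 there is one change, (iodo in place of bromo on an aromatic carbon), and it brought a 3.1-fold higher number from compound 3 to compound 1 (0.50 log units; beyond the scatter).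

Compound 4, `O=C(O)/C(S)=C/c1cccc(I)c1`, is not yet measured. It differs from compound 2 by iodo in place of bromo on an aromatic carbon. Among the compounds with values here, this is the same kind of change as the one from compound 3 to compound 1, but not the same: there the carbon ring was part of a fused or bridged system of two rings, ortho to a fused ring and meta to a fused ring, whereas here the ring is of carbon only and the place is meta to a group of 6 heavy atoms. If the change behaves in compound 2 as it did in compound 3, the step expected from compound 2 to compound 4 is a 2.9-fold higher number from compound 2 to compound 4 (0.46 log units; beyond the scatter), resting on the step of a 3.1-fold higher number from compound 3 to compound 1 (0.50 log units; beyond the scatter). Compound 4 is therefore estimated at 24000 nM, within 8000 nM to 70000 nM.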

Compound 4, half-maximal inhibitory concentration: 23900 nM
Estimate against measurement, compound 4: 1.0-fold (0.00 log units) above; low and high end bracket the measured number.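

In this assay, iodo in place of bromo gave a 2.8-fold higher number from compound 2 to compound 4 (0.45 log units; beyond the scatter), so the change weakened inhibition on this core too, even though the numbers for compound 2 and compound 4 lie far higher than those on the core of compound 3. Set side by side, the two steps agree: the same change on two cores in this assay, a 3.1-fold higher number (0.50 log units; beyond the scatter) from compound 3 to compound 1 and a 2.8-fold higher number (0.45 log units; beyond the scatter) from compound 2 to compound 4, 1.1-fold (0.04 log units) apart, within the scatter of two such steps. Within the data shown here, this shows that, for these two cores, the size of the step carried over from one to the other, but it rests on only one pair of compounds per core and says nothing about a third core, about other places on the ring, or about why iodo gives the higher number.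

The compounds shown leave open how a smaller halogen such as fluoro or chloro, or a group of another kind such as an amine or a methoxy group, would compare with bromo and iodo. On these data alone, all four compounds also carry the same carboxylic acid and thiol, so what an amide or a hydroxyl group in those places would do remains open as well.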